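Removing an Amino Group: Expected Effect on Growth Inhibition

This account rests on a few compounds, and the source may have more. Where it says the series, first, only, none or still open, it means among the compounds named here.

All numbers here come from a functional assay on SK-OV-3 cells (Homo sapiens) for cytotoxicity, read by sulforhodamine B assay, with a stated time of 48 h; on this read-out lower numbers stand for stronger inhibition of growth and higher numbers for weaker inhibition of growth.

Compound 1, `Nc1nc(Cl)c2ncn(Cc3ccccc3CCl)c2n1`, gives 15500 nM.
Compound 2, `Nc1nc(Cl)c2ncn(Cc3ccc(CCl)cc3)c2n1`, gives 15100 nM.
Compound 3, `ClCc1cccc(Cn2cnc3nc(Cl)nc(Cl)c32)c1`, gives "not determined" (no result reported) in this assay, so no number is reported for it.

Only compound 1 and compound 2 carry a number. The two values lie within the usual scatter of repeated measurements, so no order between them can be read from the data, and neither can be called the stronger or weaker of the pair. Compound 3 contributes no number at all.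

Compound 4, `ClCc1ccccc1Cn1cnc2c(Cl)ncnc21`, is the compound still to be measured. It differs from compound 1 in a single place: hydrogen in place of amino on an aromatic carbon. For the measured compounds named here, no pair of measured compounds shows this same change, so the data give no direct measure of what it does to growth inhibition. Without such a reference, the most defensible expectation is a step of modest size, in either direction, and quite possibly none beyond the scatter.

Compound 4 is therefore expected to give about 20000 nM in this assay, with an estimated range from 7000 nM to 60000 nM. The expected step of a 1.3-fold higher number from compound 1 to compound 4 (0.11 log units; within the scatter) is small and is not expected to exceed the usual scatter by much.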

Compound 4, concentration for 50% growth inhibition: 4170 nM
Compound 4: the middle estimate sits 4.8-fold (0.68 log units) above what was measured; measured number outside the range, below it.
By their numbers in this assay, from the lowest: compound 4; then compounds 2 and 1 (each within the scatter of the next).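

In this assay, replacing the amino group with hydrogen on the aromatic carbon between two ring nitrogen atoms gives a 3.7-fold lower number from compound 1 to compound 4 (0.57 log units; beyond the scatter). This single swap therefore moves the result by a modest amount, and the direction is toward stronger inhibition of growth, so in this pair the amino group is not required for the activity and what sits at this position does matter. The data show the size and direction of this step, but no measurement here accounts for it.

The compounds shown leave open whether hydrogen is the best choice at this carbon, or whether a methyl group, a methoxy group or a fluorine atom would give a still lower or a higher number. On these data alone, it also remains open whether the same change would give a step of similar size when made on compound 2, which also carries the amino group.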